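The source may hold more compounds than are shown below. What is called first, only, known or untested is meant among the compounds shown, and "the series" means these compounds.

Measured compounds:
compound 1, `C/C(C(=O)NC1CC1)=C(\C)c1ccc(C)cc1`, 280 mg/kg
compound 2, `C/C(C(=O)NC1CC1)=C(\C)c1ccccc1`, 400 mg/kg
compound 3, `C#CCNC(=O)/C(C)=C(\C)c1ccccc1`, 150 mg/kg

All three compounds were tested in a toxicity assay on the whole organism (strain Icem-CET (SPF Caw)) for cytotoxicity, with Mus musculus as the target; on this read-out lower numbers stand for an effect already at smaller amounts and higher numbers for an effect only at larger amounts of compound. Compound 1 and compound 2 share one core, while compound 3 carries a different one; the difference between the two cores is not broken down here. Within the shared core, compound 2 gives 400 mg/kg and compound 1 gives 280 mg/kg, so that the step of a 1.4-fold lower number from compound 2 to compound 1 (0.15 log units; within the scatter) goes with the change (methyl in place of hydrogen on an aromatic carbon). Compound 3 gives 150 mg/kg; its gap to compound 1 lies within the scatter, whereas its gap to compound 2 lies beyond it.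

Compound 4, `C#CCNC(=O)/C(C)=C(\C)c1ccc(C)cc1`, has not been measured yet. Among the compounds with values here, it differs from compound 3 by methyl in place of hydrogen on an aromatic carbon, and this is the same change as the one from compound 2 to compound 1, made at the same place, on the core of compound 3 instead. Because that earlier step was a 1.4-fold lower number from compound 2 to compound 1 (0.15 log units; within the scatter), a step of similar size is expected here, even though it rests on a single prior example and on a different core. This expected step, a 1.4-fold lower number from compound 3 to compound 4 (0.13 log units; within the scatter), is small and stays within the usual scatter. Compound 4 is therefore expected to give about 110 mg/kg, most likely between 55 mg/kg and 220 mg/kg.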

Compound 4, dose for half-maximal effect: 120 mg/kg
Estimate against measurement, compound 4: 1.1-fold (0.04 log units) below, within the range that was stated.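

In this assay, methyl in place of hydrogen on an aromatic carbon gives a 1.3-fold lower number from compound 3 to compound 4 (0.10 log units; within the scatter), and this step agrees with the one seen earlier on the other core: the same change on two cores in this assay, a 1.4-fold lower number (0.15 log units; within the scatter) from compound 2 to compound 1 and a 1.3-fold lower number (0.10 log units; within the scatter) from compound 3 to compound 4, 1.1-fold (0.06 log units) apart, within the scatter of two such steps On these two cores, then, the change behaves alike, and the step measured on one core was a fair guide to the step on the other. This does not show that the methyl truly shifts the dose at all, since each step on its own lies within the scatter and could arise from repeating the measurement, and two cores say nothing about how the change would behave on a third.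

The compounds shown carry only hydrogen or methyl on the ring, so it remains open whether ethyl, methoxy, chlorine, an amine or a carboxylic acid at the same place would give a step that stands clear of the scatter, and whether such a step would also carry from one core to the other. As far as these compounds go, it also remains open how methyl would behave on the other carbons of the ring, where a step of a different size could appear.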